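The compounds below may be only part of what the source reports. "The series", "measured", "known", "first", "only" and "open" are said of these compounds alone.

Among the compounds with values here, in a functional assay on A375P cells (Homo sapiens) for inhibition, read by MTT assay, with a stated time of 24 h (on this read-out lower numbers stand for stronger inhibition of growth and higher numbers for weaker inhibition of growth), compound 2 `COc1ccc(Cn2ncc3c2NC(=O)CC(c2cccc(NC(=O)Nc4cccc(Cl)c4)c2)=N3)cc1` gives 910 nM, the only actual number among the three compounds tested. Compound 1 `Cc1cn(-c2cc(C(=O)Nc3cccc(C4=Nc5cnn(Cc6ccccc6)c5NC(=O)C4)c3)cc(C(F)(F)F)c2)cn1` reads > 30000 nM, which is a limit of the assay and not a number. Compound 3 `O=C1CC(c2cccc(NC(=O)Nc3ccc(Cl)c(Cl)c3)c2)=Nc2cn[nH]c2N1` reads > 30000 nM, which is likewise a limit. Compound 4 `COc1ccc(Cn2ncc3c2NC(=O)CC(c2cccc(NC(=O)Nc4cccc(C(F)(F)F)c4)c2)=N3)cc1` keeps the structure of compound 2 except for one change: trifluoromethyl in place of chloro on an aromatic carbon, meta to a large group (trifluoromethyl in place of chloro on an aromatic carbon). Within the data shown here, no measured pair of compounds differs at this place, so there is no direct precedent for the change. In this assay, a 1.1-fold higher number from compound 2 to compound 4 (0.04 log units; within the scatter) is expected to stay within the usual scatter, with no direction favoured. For compound 4 the estimated value is 1000 nM, with an expected range from 350 nM to 3500 nM.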

Compound 4, concentration for 50% growth inhibition: 250 nM
The estimate for compound 4 lay 4.0-fold (0.60 log units) above the measured number, outside the stated range (below it).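

In this assay, trifluoromethyl in place of chloro on an aromatic carbon, meta to a large group, gives a 3.6-fold lower number from compound 2 to compound 4 (0.56 log units; beyond the scatter) as the first step read at this place. The number here therefore responds to the group on this carbon, and the entering group, with its 4 heavy atoms against 1, keeps growth inhibition measurable. No measurement shown here explains the step. With a single pair at this place, the compounds shown leave open whether fluoro, methoxy or nitrile would follow trifluoromethyl. They also leave open whether the same exchange elsewhere on this ring would give a similar step.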